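The source may hold more compounds than are shown below. What is called first, only, known or untested is meant among the compounds shown, and "the series" means these compounds.

Measured compounds in a functional assay on T47D cells (Homo sapiens) for cytotoxicity, read by sulforhodamine B assay, with a stated time of 48 h, tested at 0.1 uM; a higher number here means a weaker effect of the compound at the concentration tested, a lower number a stronger effect:
compound 1 `COc1cc(-c2cc(/C=C/C(=O)c3ccc(N)cc3)[nH]n2)cc(OC)c1OC` gives 85%;
compound 2 `COc1ccc(-c2cc(/C=C/C(=O)c3ccc(N)cc3)[nH]n2)cc1OC` gives 90%;
compound 3 `COc1cc(C(=O)/C=C/c2cc(-c3cc(OC)c(OC)c(OC)c3)n[nH]2)cc(OC)c1OC` gives 92%.

Compound 1 and compound 2 differ by hydrogen in place of methoxy on an aromatic carbon, and the step in this assay is a number 5 percentage points higher from compound 1 to compound 2 (within the scatter). Compound 3 stands on a different core; the difference between the two cores is not broken down here, and its value sits within the scatter of both compound 1 and compound 2.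

Compound 4 `COc1ccc(-c2cc(/C=C/C(=O)c3cc(OC)c(OC)c(OC)c3)[nH]n2)cc1OC` is not yet measured. It differs from compound 3 by hydrogen in place of methoxy on an aromatic carbon, the same change as from compound 1 to compound 2. Because a number 5 percentage points higher from compound 1 to compound 2 (within the scatter) lies within the scatter, the step from compound 3 to compound 4 is expected to be about as small, a number 1 percentage points higher from compound 3 to compound 4 (within the scatter). Compound 4 is therefore estimated at 93% in this assay, between 82% and 100%.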

Compound 4, a percentage reported as activity, at one concentration (the size of the read-out at that concentration, not a potency): 83%
Beside the measured number, compound 4's estimate is 10 percentage points above it, and the stated range covers the measured number.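

In this assay hydrogen in place of methoxy on an aromatic carbon gives a number 9 percentage points lower from compound 3 to compound 4 (within the scatter) on the core of compound 3. Set beside the same change on the core of compound 1, the two steps do not differ by more than the scatter allows: the same change on two cores in this assay, a number 5 percentage points higher (within the scatter) from compound 1 to compound 2 and a number 9 percentage points lower (within the scatter) from compound 3 to compound 4, 14 percentage points apart, within the scatter of two such steps

This is consistent with a change that has little effect on either core, but it does not show that the change carries over from one core to the other, since neither step can be told from the scatter.

In the compounds shown, only hydrogen stands in place of methoxy, so a hydroxy group, chlorine or a longer chain such as ethoxy at that place remains open. From the compounds shown here alone, with one concentration in this assay, it also remains open whether the two cores would separate at other concentrations.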